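The source may hold more compounds than are shown below. What is called first, only, known or untested is meant among the compounds shown, and "the series" means these compounds.

In a functional assay on the whole organism with Mus musculus as the target (a lower number here means that less compound is needed, a higher number that more compound is needed for the effect), compound 1 (`CCN(C)C(=O)/C=C1\CCc2c(F)cc(F)cc21`) gives 56 mg/kg while compound 2 (`NC(=O)/C=C1/CCc2ccc(F)cc21`) gives 64 mg/kg and compound 3 (`CNC(=O)/C=C1\CCc2c(F)cc(F)cc21`) gives 45 mg/kg on the same test. These three values lie within the usual scatter of one another, so compound 3 stands level with the other two.

Compound 4 (`O=C(/C=C1\CCc2c(F)cc(F)cc21)NC1CC1`) has not yet been measured. Compared with compound 3 it carries cyclopropyl in place of methyl on an amide-type nitrogen and the rest of the structure stays the same.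

Among the measured compounds shown here, one measured step bears on this nitrogen. Hydrogen in place of ethyl gave a 1.2-fold lower number from compound 1 to compound 3 (0.09 log units; within the scatter) and this is the only direct evidence, since compound 2 differs from compound 3 in more than one place. For the measured compounds named here, no measured compound carries cyclopropyl, so the guidance is indirect. On the strength of that single small step, no change beyond the scatter is expected in this assay and neither direction is favoured. The expected move is a 1.1-fold higher number from compound 3 to compound 4 (0.03 log units; within the scatter) and it would stay inside the scatter. For compound 4 the estimated value is 48 mg/kg with an expected range from 25 mg/kg to 90 mg/kg on this test.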

Compound 4, dose for half-maximal effect: 62 mg/kg
Compound 4: the middle estimate sits 1.3-fold (0.11 log units) below what was measured, within the range that was stated.
By their numbers in this assay, from the lowest: compounds 3, 1, 4 and 2 (each within the scatter of the next).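

In this assay, among the compounds shown here, the amide-type nitrogen now carries a ring for the first time, and cyclopropyl in place of methyl gave a 1.4-fold higher number from compound 3 to compound 4 (0.14 log units; within the scatter) even though the group entering has three heavy atoms where the one leaving has a single heavy atom. Cyclopropylamino in place of ethyl(methyl)amino on the carbonyl carbon gave a 1.1-fold higher number from compound 1 to compound 4 (0.04 log units; within the scatter) and so, among compounds 1, 3 and 4, a branched ring-bearing substituent on this nitrogen stands level with the two open-chain forms, which extends the flat picture from a single step to three linked steps. No independent measurement bears on this result, so the flat reading rests on these whole-organism doses alone.

What the compounds leave open is whether this nitrogen stays as flat with something much larger or of another kind on it, such as a longer chain, a phenyl ring, or a chain ending in an amine or a carboxylic acid. On these data alone, it is also open how the unsubstituted amide would compare on the core of compound 4, since compound 2 differs from these compounds in more than one place.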